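Aryl substituent changes on the biaryl amide series

The compounds below may be only part of what the source reports. "The series", "measured", "known", "first", "only" and "open" are said of these compounds alone.

- Compound 1, `Cc1cccc(-c2ccc(N(C[C@@H](N)CC(C)C)C(=O)[C@@H]3C[C@H]3c3ccccc3)cc2)c1`: 1200 nM
- Compound 2, `COc1ccc(-c2ccc(N(C[C@@H](N)CC(C)C)C(=O)[C@@H]3C[C@H]3c3ccccc3)cc2)cc1`: 330 nM
- Compound 3, `CC(C)C[C@H](N)CN(C(=O)[C@@H]1C[C@H]1c1ccccc1)c1ccc(-c2cccc(C#N)c2)cc1`: 4500 nM

In a functional assay for agonist activity at G protein-coupled receptor 88 (Homo sapiens), read by HTRF and cAMP accumulation (a lower number here means that less compound is needed, a higher number that more compound is needed for the effect), compound 3 gives the highest number of the three: it sits a 3.8-fold higher number from compound 1 to compound 3 (0.57 log units; beyond the scatter) and a 14-fold higher number from compound 2 to compound 3 (1.13 log units; beyond the scatter). Compound 4, `CC(C)C[C@H](N)CN(C(=O)[C@@H]1C[C@H]1c1ccccc1)c1ccc(-c2ccccc2Cl)cc1`, differs from compound 3 by 2-chlorophenyl in place of 3-cyanophenyl on an aromatic carbon. Within the data shown here, the steps that bear on this are the cyano-for-methyl change, a 3.8-fold higher number from compound 1 to compound 3 (0.57 log units; beyond the scatter), and the swap of the whole aryl ring, a 14-fold higher number from compound 2 to compound 3 (1.13 log units; beyond the scatter); both show that the cyano-bearing ring carries the largest number in this set. Among the measured compounds shown here, a 2-chlorophenyl ring has no measured precedent here, so the step is expected to be modest and downward in this assay. For compound 4 the estimate is 1500 nM, with a range of 500 nM to 5000 nM, that is an expected 3.0-fold lower number from compound 3 to compound 4 (0.48 log units; beyond the scatter).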

Compound 4, half-maximal effective concentration: 3800 nM
Compound 4: middle estimate off by 2.5-fold (0.40 log units), on the low side, within the range that was stated.
By their numbers in this assay, from the lowest: compound 2; then compound 1; then compounds 4 and 3 (each within the scatter of the next).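

In this assay, 2-chlorophenyl and 3-cyanophenyl on this aromatic carbon, para to a large group, are not separated (a 1.2-fold lower number from compound 3 to compound 4 (0.07 log units; within the scatter)), so high numbers at this position are not confined to the nitrile-bearing ring. The 2-chlorophenyl ring also falls well short of 4-methoxyphenyl (a 12-fold higher number from compound 2 to compound 4 (1.06 log units; beyond the scatter)) and less far short of 3-methylphenyl (a 3.2-fold higher number from compound 1 to compound 4 (0.50 log units; beyond the scatter)), which leaves 4-methoxyphenyl with the lowest number in the set. No measurement shown accounts for these differences.

Still open, on these data alone, is whether the low number of compound 2 belongs to the methoxy group itself. A longer ethoxy or propoxy chain, or a hydroxyl or an amine on that ring, would address this.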